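Cytotoxicity notes on the series: methyl to ethyl

The source may report more compounds than this note shows. Statements on the series, on what has been measured and on what is new or still open speak of the compounds shown alone.

Three compounds of the series have been run in an ADME assay on HEK293 cells (Homo sapiens) for cytotoxicity, read by MTT assay, with a stated time of 44 h; on this read-out lower numbers stand for stronger inhibition and higher numbers for weaker inhibition. Compound 3 `Cc1ccc(C2ON=C(c3ccc(Cl)cc3)O2)cc1` sits at the ceiling of that measurement and gives > 100000 nM in this assay, which is a limit and not a number. Compound 2 `Clc1ccc(C2=NOC(c3ccc(Cl)cc3)O2)cc1` likewise returns only a limit, > 100000 nM. Compound 1 `CCc1ccc(C2ON=C(c3ccccc3Cl)O2)cc1` also returns only a limit, > 100000 nM. Hence a step that the two limits leave unreadable from compound 2 to compound 3 cannot be sized, and the limit of > 100000 nM in this assay, at which 3 of the 3 values shown sit, is the whole of the evidence available. Compound 4 `CCc1ccc(C2ON=C(c3ccc(Cl)cc3)O2)cc1` is the next member. It differs from compound 3 by methyl in place of hydrogen on a saturated chain carbon bound to an aromatic carbon. For the measured compounds named here, no measured step reproduces this change: the only neighbouring step, the one from compound 2 to compound 3, is unreadable, and compound 1, which also carries the ethyl group, differs from compound 4 in more than one place, so its value shows only that it too sits at the limit. With every shown value at the limit, the step of a number no higher from compound 3 to compound 4 (the limit leaves the size open) is expected to be none beyond the scatter. Compound 4 is therefore estimated at 100000 nM, with a range from 50000 nM to 300000 nM, and is expected most likely to be reported again only as a limit.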

Compound 4, half-maximal inhibitory concentration: > 100000 nM
Compound 4: no number, only a limit; the forecaster's own chance of this, stated with the estimate: 90%; the middle value sits exactly at the limit.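

The steps from compound 2 and from compound 3 to compound 4 cannot be read, since every value is a limit: the limit of > 100000 nM in this assay, at which 4 of the 4 values shown sit.

The compounds shown leave open how large the effect of any of these changes is, and whether any member of the series reaches a readable value.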